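Swapping a hydroxyl for an acetate on the ester side chain

The source may hold more compounds than are shown below. What is called first, only, known or untested is meant among the compounds shown, and "the series" means these compounds.

Measured compounds:
- Compound 1 `CCCCC(O)CC(=O)O[C@H](CC=C(C)C)C1=CC(=O)c2c(O)ccc(O)c2C1=O`: 45300 nM
- Compound 2 `CC[C@](C)(O)CC(=O)O[C@H](CC=C(C)C)C1=CC(=O)c2c(O)ccc(O)c2C1=O`: 20500 nM
- Compound 3 `CCC(O)(CC)CC(=O)O[C@H](CC=C(C)C)C1=CC(=O)c2c(O)ccc(O)c2C1=O`: 67000 nM

All three share one core and differ only in the group on a saturated chain carbon bound to a carbonyl carbon. In a functional assay on DU-145 cells (Homo sapiens) for cytotoxicity, read by MTT assay (a higher number here means a weaker inhibitor, a lower number a stronger inhibitor), compound 1 gives 45300 nM, the second highest of the three numbers; the step of a 1.5-fold higher number from compound 1 to compound 3 (0.17 log units; within the scatter) lies within the scatter, while a 2.2-fold lower number from compound 1 to compound 2 (0.34 log units; beyond the scatter) is modest but real.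

Compound 4 `CCCC(CC(=O)O[C@H](CC=C(C)C)C1=CC(=O)c2c(O)ccc(O)c2C1=O)OC(C)=O` carries the change (1-acetoxybutyl in place of 1-hydroxypentyl on a saturated chain carbon bound to a carbonyl carbon). Among the measured compounds shown here, none of the measured steps touches an acetate; they only move carbons around a hydroxyl, and the largest of them, a 3.3-fold higher number from compound 2 to compound 3 (0.51 log units; beyond the scatter), is still modest. The step of a 1.1-fold lower number from compound 1 to compound 4 (0.05 log units; within the scatter) is therefore expected to be small, with the estimate for compound 4 at 40000 nM and a range from 15000 nM to 110000 nM.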

Compound 4, half-maximal inhibitory concentration: 55700 nM
Beside the measured number, compound 4's estimate is 1.4-fold (0.14 log units) below it; the measured number falls inside the stated range.
By their numbers in this assay, from the lowest: compound 2; then compounds 1, 4 and 3 (each within the scatter of the next).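

In this assay, a group with 0 hydrogen-bond donors is tolerated on this saturated chain carbon bound to a carbonyl carbon: replacing 1-hydroxypentyl with 1-acetoxybutyl gives a 1.2-fold higher number from compound 1 to compound 4 (0.09 log units; within the scatter). The step of a 1.2-fold lower number from compound 3 to compound 4 (0.08 log units; within the scatter) also lies within the scatter, and only a 2.7-fold higher number from compound 2 to compound 4 (0.43 log units; beyond the scatter) goes beyond it, modestly. No evidence is available to explain these numbers.

The acetate and the change from pentyl to butyl arrive together, so a 1-hydroxybutyl group would be needed to separate them. Going by these compounds, what an amine or a carboxylic acid would do at this place remains open.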